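Cytotoxicity Limits Across Four Closely Related Compounds

This account rests on a few compounds, and the source may have more. Where it says the series, first, only, none or still open, it means among the compounds named here.

In an ADME assay on MT4 cells (Homo sapiens) for cytotoxicity, read by MTT assay (a lower number here means that less compound is tolerated, a higher number that more compound is tolerated), three compounds have been examined so far, and none of them gave a number. Compound 1 `O=C(CSc1nc(Cc2c(Cl)cccc2Cl)cc(=O)[nH]1)c1ccc(F)cc1` is recorded only as a limit, > 59000 nM. Compound 2 `COc1ccc(C(=O)CSc2nc(Cc3c(Cl)cccc3Cl)cc(=O)[nH]2)cc1` likewise reached only a limit, > 11000 nM. Compound 3 `CCc1c(Cc2c(Cl)cccc2Cl)nc(SCC(=O)c2ccc(F)cc2)[nH]c1=O` also stopped at a limit, > 55000 nM. Every value is a limit. The two steps that join them therefore cannot be sized: a step that the two limits leave unreadable from compound 1 to compound 2, with the change (methoxy in place of fluoro on an aromatic carbon), and a step that the two limits leave unreadable from compound 1 to compound 3, with the change (ethyl in place of hydrogen on an aromatic carbon).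

Compound 4 `CCc1c(Cc2c(Cl)cccc2Cl)nc(SCC(=O)c2ccc(OC)cc2)[nH]c1=O` has not yet been measured in this assay. It stands to compound 3 as compound 2 stands to compound 1, the same change made on the core of compound 3: methoxy in place of fluoro on an aromatic carbon. The cores of compound 1 and compound 3 differ as described by ethyl in place of hydrogen on an aromatic carbon.

The account of compound 1 and compound 2 rests on the limits the limit of > 59000 nM in this assay, at which 1 of the 3 values shown sits, and (the limit of > 11000 nM in this assay, at which 1 of the 3 values shown sits), which leave the size of the change unreadable. For compound 3 and compound 4 the same is expected, since compound 3 sits at the limit (the limit of > 55000 nM in this assay, at which 1 of the 3 values shown sits), so the step from compound 3 to compound 4 is expected to be about a number no higher from compound 3 to compound 4 (the limit leaves the size open). Compound 4 is therefore estimated to be tolerated up to about 55000 nM, most likely again reported only as a limit, between 11000 nM and 200000 nM.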

Compound 4, half-maximal cytotoxic concentration: > 54000 nM
Compound 4: only a limit was reported; the forecaster's own chance of this, stated with the estimate: 85%; the middle value does not contradict the limit.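

In this assay compound 4 gives > 54000 nM, which is a limit and not a number. Among the compounds shown here, compound 2 and compound 3 are also recorded only as limits, so neither the step to compound 4 from compound 3 nor the one from compound 2 can be read. The compounds shown leave open whether methoxy in place of fluoro or ethyl in place of hydrogen changes the tolerated concentration at all.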